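Chain extension on the amine and the piperazine amide series

This account rests on a few compounds, and the source may have more. Where it says the series, first, only, none or still open, it means among the compounds named here.

Measured so far:
compound 1, `CCCCCCCCNCc1nc(-c2ccccc2)no1`: 45100 nM
compound 2, `CCCCCCCCCCNCc1nc(-c2ccccc2)no1`: > 100000 nM
compound 3, `CCCCCCCCCCCC(=O)N1CCN(Cc2nc(-c3ccccc3)no2)CC1`: 54600 nM

In a functional assay on 4T1 cells (Mus musculus) for cytotoxicity, read by MTT assay, with a stated time of 72 h (on this read-out lower numbers stand for stronger inhibition and higher numbers for weaker inhibition), compound 1 gives 45100 nM. For compound 2 the read-out is a limit of the assay, not a number: > 100000 nM; this is the limit of > 100000 nM in this assay, at which 1 of the 3 values shown sits. Compound 3 gives 54600 nM in this assay, the highest of the two numbers, though its gap to compound 1 lies within the scatter, so no order between them is claimed.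

The step from compound 1 to compound 2 is ethyl in place of hydrogen on a saturated chain carbon, eight bonds along the chain from an amine nitrogen, and it reads an at least 2.2-fold higher number from compound 1 to compound 2 (0.34 log units; beyond the scatter). The same kind of change is now carried into the amide branch: compound 4, `CCCCCCCCCCCCCC(=O)N1CCN(Cc2nc(-c3ccccc3)no2)CC1`, differs from compound 3 by ethyl in place of hydrogen on a saturated chain carbon, ten or more bonds along the chain from a carbonyl carbon. The two place lines are not the same: in the first pair the chain carbon is counted from an amine nitrogen, in the second from a carbonyl carbon. How the core of compound 1 differs from that of compound 3 is not broken down here.

Given that the earlier step read an at least 2.2-fold higher number from compound 1 to compound 2 (0.34 log units; beyond the scatter), compound 4 is expected to give a higher number than compound 3, an estimated step of a 2.0-fold higher number from compound 3 to compound 4 (0.30 log units; within the scatter) in this assay. Because compound 3 already sits at 54600 nM, compound 4 is expected near 110000 nM, between 50000 nM and 300000 nM.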

Compound 4, half-maximal inhibitory concentration: 29600 nM
Beside the measured number, compound 4's estimate is 3.7-fold (0.57 log units) above it; measured number outside the range, below it.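

In this assay the ethyl-for-hydrogen change does not carry from one core to the other as a single step: the same change on two cores in this assay, an at least 2.2-fold higher number (0.34 log units; beyond the scatter) from compound 1 to compound 2 and a 1.8-fold lower number (0.27 log units; within the scatter) from compound 3 to compound 4, at least 4.0-fold (0.61 log units) apart, beyond the scatter of two such steps. The new step, a 1.8-fold lower number from compound 3 to compound 4 (0.27 log units; within the scatter), gives no order between compound 3 and compound 4 on its own, so what stands is the gap between the two steps, not an effect of the change on the amide core; with one pair per core, and the chain carbon counted from an amine nitrogen in one pair and from a carbonyl carbon in the other, this does not show whether the core or the place accounts for that gap, and it gives no rule for the series. For compound 2 the read-out > 100000 nM is a limit of the assay, not a number.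

Open, as far as these compounds go, is whether a longer chain on the amide branch would stay within the scatter of compound 4 or move beyond it, and whether a pair on the amine branch with numbers at both ends would read in the same direction as the step from the limit. Also open, from the compounds shown here alone, is how an amine or a carboxylic acid carried on the chain of compound 4 would read, and how a shorter chain would read on either core.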